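Anilino swap on the shared core: compound 3 to compound 4

The compounds below may be only part of what the source reports. "The series", "measured", "known", "first", "only" and "open" are said of these compounds alone.

Compound 3 `N#Cc1c(Nc2cccc(Cl)c2)nc(SCc2cn(Cc3ccccc3Cl)nn2)nc1-c1ccccc1` is measured in a functional assay on MGC-803 cells (Homo sapiens) for inhibition, read by MTT assay, with a stated time of 72 h (on this read-out higher numbers stand for weaker inhibition and lower numbers for stronger inhibition), and gives 15800 nM, the second highest of the three numbers recorded. Compound 1 `C#CCSc1nc(Nc2ccc(OC)cc2)c(C#N)c(-c2ccccc2)n1` gives 28400 nM in this assay, within the scatter of compound 3. Within the data shown here, compound 2 `N#Cc1c(Nc2ccccc2Cl)nc(SCc2cn(Cc3ccccc3Cl)nn2)nc1-c1ccccc1` gives 4640 nM, and the step of a 3.4-fold higher number from compound 2 to compound 3 (0.53 log units; beyond the scatter) is the only measured change on a nitrogen on an aromatic ring. Compound 4 `N#Cc1c(Nc2ccc(F)cc2)nc(SCc2cn(Cc3ccccc3Cl)nn2)nc1-c1ccccc1` differs from compound 3 by 4-fluorophenyl in place of 3-chlorophenyl on a nitrogen on an aromatic ring. Among the measured compounds shown here, that single modest step bears on the change, but no measured pair exchanges chlorine for fluorine, so the direction is uncertain and a step no larger than the modest one already seen is expected, likely within the scatter. Compound 4 is therefore estimated at 12000 nM, with a range of 4000 nM to 40000 nM. That estimate means an expected step of a 1.3-fold lower number from compound 3 to compound 4 (0.12 log units; within the scatter).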

Compound 4, half-maximal inhibitory concentration: 8740 nM
Estimate against measurement, compound 4: 1.4-fold (0.14 log units) above, within the range that was stated.
By their numbers in this assay, from the lowest: compounds 2, 4, 3 and 1 (each within the scatter of the next, the first and the last beyond it).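

In this assay, a 4-fluorophenyl on this nitrogen stays within the scatter of both chlorophenyl compounds (a 1.8-fold lower number from compound 3 to compound 4 (0.26 log units; within the scatter); a 1.9-fold higher number from compound 2 to compound 4 (0.27 log units; within the scatter)). Compound 4 therefore does not separate from either compound 2 or compound 3, even though those two lie beyond the scatter of each other. No supporting measurement is available to explain this result.

The identity of the halogen and its place on the ring both change from compound 3 to compound 4, so their contributions remain unseparated. From the compounds shown here alone, how a phenyl bearing an amine or a carboxylic acid would read here also remains open.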